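Three aminothiophene piperazines, a fourth awaits measurement

A few compounds are considered here, and "the series" means these few. Any claim that something is new, unique, unknown or untested is made for them only; others in the source may bear on it.

Compound 1 `Nc1scc(CN2CCN(c3cc(Cl)cc(Cl)c3)CC2)c1C(=O)c1ccc(Cl)cc1`, compound 2 `Nc1scc(CN2CCN(c3ccc(F)cc3F)CC2)c1C(=O)c1ccc(Cl)cc1` and compound 3 `Nc1scc(CN2CCN(CCCc3ccc(Cl)cc3)CC2)c1C(=O)c1ccc(Cl)cc1` share one core and differ only in the group on an amine nitrogen in a ring. In an assay on CHO cells for displacement of a labelled ligand from adenosine receptor A1 (Homo sapiens), read by scintillation counting, with a stated time of 120 min, tested at 10 uM (on this read-out lower numbers stand for less inhibition and higher numbers for more inhibition at the one concentration tested (going by the name of the read-out)), compound 1 gives 1%, compound 2 gives 1% and compound 3 gives 0%. The steps of a number 1 percentage points lower from compound 1 to compound 3 (within the scatter) and a number 1 percentage points lower from compound 2 to compound 3 (within the scatter) show that compound 3 sits within the scatter of both others, so none of the three can be told apart here. Compound 4 `Nc1scc(CN2CCN(c3cccc(Cl)c3)CC2)c1C(=O)c1ccc(Cl)cc1` carries the change (3-chlorophenyl in place of 3-(4-chlorophenyl)propyl on an amine nitrogen in a ring). Every change of this group seen so far, including no change at the digits printed from compound 1 to compound 2 (within the scatter), left the read-out unchanged within the scatter, so the step of a number 1 percentage points higher from compound 3 to compound 4 (within the scatter) is expected to stay within the scatter as well. Compound 4 is therefore estimated at 1%, between -6% and 9%.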

Compound 4, a percentage reported as inhibition, at one concentration (the size of the read-out at that concentration, not a potency): 0%
Beside the measured number, compound 4's estimate is 1 percentage points above it; the range from low to high includes it.
By their numbers in this assay, from the lowest: compounds 3, 4, 1 and 2 (each within the scatter of the next).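

In this assay, 3-chlorophenyl in place of 3-(4-chlorophenyl)propyl gives no change at the digits printed from compound 3 to compound 4 (within the scatter), so this position now shows no difference with or without the propyl chain. Hydrogen in place of one chloro on the aromatic ring gives a number 1 percentage points lower from compound 1 to compound 4 (within the scatter), and 3-chlorophenyl in place of 2,4-difluorophenyl gives a number 1 percentage points lower from compound 2 to compound 4 (within the scatter), so the number of halogens on this ring shows no effect either. No separate evidence bears on this result.

All four groups on this nitrogen carry a halogenated benzene ring. From the compounds shown here alone, whether a carboxylic acid, an amine or an unsubstituted phenyl there would read any differently remains open.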